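This account rests on a few compounds, and the source may have more. Where it says the series, first, only, none or still open, it means among the compounds named here.

In a functional assay on HEK-293T cells (Homo sapiens) for cytotoxicity, read by MTT assay (a higher number here means that more compound is tolerated, a lower number that less compound is tolerated), compound 1 `COc1ccc(-c2nc3cc(C)ccn3c2Nc2cc(OC)c(OC)c(OC)c2)cc1O` gives 8000 nM and compound 2 `COc1ccc(-c2nc3cnccn3c2Nc2cc(OC)c(OC)c(OC)c2)cc1` gives 54000 nM as its reading. Compound 2 therefore has the higher of the two numbers, meaning that more of it is tolerated, and the gap between them lies beyond the usual scatter of repeated measurements. These two compounds differ in more than one place, so the gap cannot be traced to any single group.

Compound 3 `COc1cc(Nc2c(-c3ccc(F)cc3)nc3cnccn23)cc(OC)c1OC` is compound 2 with one change, 4-methoxyphenyl to 4-fluorophenyl, counted as fluoro in place of methoxy on an aromatic carbon and described as fluoro in place of methoxy on an aromatic carbon, para to a large group. Going by the values given here, no measured pair shows what this swap does on its own, so the only guide is compound 2 at 54000 nM as the starting point. On that basis no change beyond the scatter is expected, and the estimated 1.2-fold lower number from compound 2 to compound 3 (0.08 log units; within the scatter) is small and slightly downward. Compound 3 is expected near 45000 nM as a middle estimate, with an estimated range of 18000 nM to 110000 nM in this assay for this cell test.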

Compound 3, concentration lethal to 50% of the cells: 36000 nM
For compound 3 the middle estimate is 1.3-fold (0.10 log units) above the measured one, within the range that was stated.
By their numbers in this assay, from the lowest: compound 1; then compounds 3 and 2 (each within the scatter of the next).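

In this assay, putting fluoro in place of methoxy on an aromatic carbon, para to a large group, gives a 1.5-fold lower number from compound 2 to compound 3 (0.18 log units; within the scatter), so this cell test does not tell the two compounds apart. At this position, then, the methoxy group, with its carbon, its oxygen and its one hydrogen-bond acceptor, can give way to a single fluorine atom without a shift that stands out from the ordinary spread of repeated measurements. Going by these compounds alone, compound 1 and compound 2 differ in more than one place, so this is the only comparison so far that ties a result to one group, and nothing available explains why the swap leaves the reading within that spread.

Going by these compounds, whether this position tolerates other groups just as readily remains open, since a single swap says nothing about an amine, a carboxylic acid or a longer chain such as ethoxy on the same aromatic carbon. On these data alone, it also remains open whether fluoro in place of methoxy would behave the same way on a different core, such as the core of compound 1.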